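Cinnamate glycolamide esters: a morpholine to furfuryl swap

A few compounds are considered here, and "the series" means these few. Any claim that something is new, unique, unknown or untested is made for them only; others in the source may bear on it.

Compound 1 `COCOc1cc(/C=C/C(=O)OCC(=O)NN2CCOCC2)ccc1OCc1ccccc1` reaches only the limit > 200000 nM in a functional assay on BEL-7404 cells (Homo sapiens) for cytotoxicity, read by MTT assay, with a stated time of 72 h; on this read-out lower numbers stand for stronger inhibition and higher numbers for weaker inhibition. Compound 2 `COc1ccc(NC(=O)COC(=O)/C=C/c2cc(OC)c(OCc3ccccc3)c(OC)c2)cc1` likewise sits at the limit > 200000 nM. Compound 3 `O=C(COC(=O)/C=C/c1ccc(O)c(O)c1)Nc1ccc(Cl)cc1` also sits at the limit > 200000 nM.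

Compound 1 therefore stands at the same assay limit as the other two measured compounds, a limit described by the limit of > 200000 nM in this assay, at which 3 of the 3 values shown sit. Among the measured compounds shown here, no single-step pair among the measured compounds exists, so no measured step size is available. Compound 4 `COCOc1cc(/C=C/C(=O)OCC(=O)NCc2ccco2)ccc1OCc1ccccc1` differs from compound 1 by the change ((furan-2-yl)methyl in place of morpholin-4-yl on an amide-type nitrogen). With all three known values at the limit, no direction can be read for this change, and any step is expected to stay within the scatter. Compound 4 is expected near 200000 nM, with a range from 50000 nM to 400000 nM, most likely reported again as a limit. The change is estimated as a number no higher from compound 1 to compound 4 (the limit leaves the size open).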

Compound 4, half-maximal inhibitory concentration: > 200000 nM
Compound 4 ended at the assay's limit; the forecaster's own chance of this, stated with the estimate: 75%; the middle value sits exactly at the limit.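

Compound 1 and compound 4 both rest on limits, so no step can be read for (furan-2-yl)methyl in place of morpholin-4-yl on an amide-type nitrogen. The compounds shown leave open which structure, if any, would give a measurable value in this assay.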